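A few compounds are considered here, and "the series" means these few. Any claim that something is new, unique, unknown or untested is made for them only; others in the source may bear on it.

Among the compounds with values here, compound 1 `CC1CCN(C2CCN(S(=O)(=O)c3ccc(-c4ccccc4)cc3)CC2)CC1` is the only compound here with a measured number: in a functional assay on DLD-1 cells (Homo sapiens) for antiproliferative activity, read by CellTiter-Glo, with a stated time of 72 h (on this read-out lower numbers stand for stronger inhibition and higher numbers for weaker inhibition), compound 1 gives 258 nM. Compound 2 `Cc1cc(C)c(S(=O)(=O)c2ccc(N3CCC(C)CC3)cc2)c(C)c1` sits at the limit of > 5000 nM in this assay, at which 1 of the 2 values shown sits; in this assay compound 2 gives > 5000 nM, which is a limit of the assay and not a number. Compound 3 `CC1CCN(C2CCN(S(=O)(=O)c3ccc(C(C)(C)C)cc3)CC2)CC1` has not been measured; it differs from compound 1 by tert-butyl in place of phenyl on an aromatic carbon. Within the data shown here, no step between measured compounds is known, so the expectation rests on compound 1 alone; the expected step is a 2.3-fold higher number from compound 1 to compound 3 (0.37 log units; beyond the scatter), a modest loss of potency beyond the usual scatter. Compound 3 is therefore estimated at 600 nM, within 150 nM to 2500 nM.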

Compound 3, half-maximal inhibitory concentration: > 5000 nM
Compound 3 was reported as a limit; the forecaster's own chance of this, stated with the estimate: 10%; middle value at least 8.3-fold (0.92 log units) away from the limit.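

At this aromatic carbon, para to a large group, phenyl does not tolerate exchange for tert-butyl: in this assay the change gives an at least 19-fold higher number from compound 1 to compound 3 (1.28 log units; beyond the scatter). Only the phenyl-bearing compound 1 keeps a measurable value in this pair, so this position is far more sensitive to this change than compound 1 alone could show. The value of compound 3 is a limit of the assay and not a number, so the true step may be larger: the limit of > 5000 nM in this assay, at which 2 of the 3 values shown sit.

As far as these compounds go, it remains open whether an aromatic ring is needed here, which a cyclohexyl or pyridyl group at this carbon would test. How a smaller group such as methoxy or chlorine would fare is also unknown.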